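The source may report more compounds than this note shows. Statements on the series, on what has been measured and on what is new or still open speak of the compounds shown alone.

Compound 3 `CN(C)Cc1csc(NC(=O)c2cc(C(C)(C)C)nn2Cc2ccccc2)n1` gives 2.6 in a physicochemical assay for lipophilicity, read by HPLC, at pH 3.0 (on this read-out lower numbers stand for lower lipophilicity and higher numbers for higher lipophilicity), level with compound 2 `CC(C)(C)c1cc(C(=O)Nc2ccncc2)n(Cc2ccccc2)n1` at 2.6, and together they are the lowest of the three numbers. Compound 1 `Cc1csc(NC(=O)c2cc(C(C)(C)C)nn2Cc2ccccc2)n1` stands highest in this assay at 4.7. The change to compound 4 `CC(C)(C)c1cc(C(=O)Nc2cccc(CN)c2)n(Cc2ccccc2)n1` is 3-(aminomethyl)phenyl in place of 4-((dimethylamino)methyl)-1,3-thiazol-2-yl on an amide-type nitrogen. Among the compounds with values here, two measured steps bear on it: a number 2.10 log units lower from compound 1 to compound 3 (beyond the scatter), and no change at the digits printed from compound 2 to compound 3 (within the scatter). Since compound 4 still carries an amine nitrogen on a chain carbon bound to an aromatic carbon, the large lowering seen in a number 2.10 log units lower from compound 1 to compound 3 (beyond the scatter) is taken to apply to compound 4 as well. In this assay compound 4 is expected to show only a number 0.30 log units lower from compound 3 to compound 4 (within the scatter), within the scatter. Compound 4 is estimated at 2.3, in a range from 1.6 to 3.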

Compound 4, distribution coefficient: 2.2
Estimate against measurement, compound 4: 0.10 log units above; the measured number falls inside the stated range.
By their numbers in this assay, from the lowest: compound 4; then compounds 2 and 3 (each within the scatter of the next); then compound 1.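

The new group gives a number 0.40 log units lower from compound 3 to compound 4 (beyond the scatter) and a number 0.40 log units lower from compound 2 to compound 4 (beyond the scatter) and also a number 2.50 log units lower from compound 1 to compound 4 (beyond the scatter) in this assay on this read-out. This position on the amide-type nitrogen can therefore go below the level shared by compound 2 and compound 3, even with a ring of carbon only in place of a ring holding hetero atoms. No measurement here gives a reason for this drop.

Still open, as far as these compounds go, is how the number would move with a plain phenyl on this nitrogen, without the aminomethyl group. A carboxylic acid or a longer amine chain on the ring also remains untested in the compounds shown.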